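The compounds below may be only part of what the source reports. "The series", "measured", "known", "first", "only" and "open" are said of these compounds alone.

Working notes on the series.

Three compounds have been run in a functional assay on CHO cells for agonist activity at Melanocortin receptor 4 (Homo sapiens), read by cAMP accumulation; a higher number here means that more compound is needed for the effect, a lower number that less compound is needed. Compound 1, `CCC(=O)N1C[C@@H](C(=O)N2CCN(c3ccc(C)cc3[C@@H](NC(=O)CCN(C)C)C(C)C)CC2)[C@H](c2ccc(Cl)cc2)C1`, gives 27 nM in this assay. Compound 2, `CNCC(=O)N[C@H](c1cc(C)ccc1N1CCN(C(=O)[C@@H]2CN(C3CCOCC3)C[C@H]2c2ccc(Cl)cc2)CC1)C(C)C`, gives 19 nM in this assay. Compound 3, `CC(C)[C@H](NC(=O)CCN(C)C)c1cccc(F)c1N1CCN(C(=O)[C@@H]2CN(C(C)C)C[C@H]2c2ccc(F)c(Cl)c2)CC1`, gives 410 nM in this assay. Compound 2 and compound 1 cannot be told apart within the usual scatter of repeated measurements; compound 3 stands clearly apart from compound 2, needing more compound for the same effect. No pair among these three differs in a single place, so no isolated step can be read off, and the comparison of compound 2 with compound 3 bundles several changes at once.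

The next compound, compound 4, `Cc1ccc(N2CCN(C(=O)[C@@H]3CN(C4CCOCC4)C[C@H]3c3ccc(Cl)cc3)CC2)c([C@@H](NC(=O)[C@@H](C)N)C(C)C)c1`, is a rearrangement of compound 2: the two share the same atoms, joined differently. The change is 1-aminoethyl in place of (methylamino)methyl on a carbonyl carbon. The amide linkage and the rest of the molecule are untouched.

Going by the values given here, no measured pair offers a step of this kind, so the expectation rests on compound 2 alone. The estimate for compound 4 is 25 nM, with a range of 8 nM to 80 nM in this assay. The expected step from compound 2 to compound 4 is a 1.3-fold higher number from compound 2 to compound 4 (0.12 log units; within the scatter), which is not expected to rise beyond the scatter in either direction.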

Compound 4, half-maximal effective concentration: 17 nM
Estimate against measurement, compound 4: 1.5-fold (0.17 log units) above, and the stated range covers the measured number.
By their numbers in this assay, from the lowest: compounds 4, 2 and 1 (each within the scatter of the next); then compound 3.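

In this assay, going by these compounds alone, 1-aminoethyl in place of (methylamino)methyl on a carbonyl carbon gives a 1.1-fold lower number from compound 2 to compound 4 (0.05 log units; within the scatter), the first step that isolates a single place. At this position, the same atoms can therefore be joined differently, with a defined stereocentre added in the entering group, without the number leaving the scatter. No available evidence bears on this result.

From the compounds shown here alone, whether the nitrogen of this side chain matters at all stays open, since both groups carry one, and a plain ethyl, a hydroxymethyl or a carboxylic acid on the same carbonyl carbon would address that, as would a longer chain such as 2-aminopropyl for the reach of the amine. The opposite configuration of the 1-aminoethyl stereocentre also remains an open question, as compound 4 shows only one of the two arrangements, so nothing here says whether this position distinguishes between them.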